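A new chain double bond on compound 1

A few compounds are considered here, and "the series" means these few. Any claim that something is new, unique, unknown or untested is made for them only; others in the source may bear on it.

Measured so far in an ADME assay on microsomes from liver (Homo sapiens) for metabolic stability; a lower number here means that the compound disappears faster, a higher number that the compound lasts longer:
Compound 1 `CC(C)C(CC1C(=O)NC(=O)N1C)c1ccc(-c2ccc3cccc(F)c3c2)[nH]c1=O` (half-life 0.153 h)
Compound 2 `CC(C)[C@@H](c1ccc(-c2ccc3cccc(F)c3c2)[nH]c1=O)[C@@H]1OC(=O)NC1=O` (a limit of the assay, not a number: > 3 h)
Compound 3 `O=C1NC(=O)/C(=C/C(c2ccccc2)c2ccc(-c3ccc4cccc(F)c4c3)[nH]c2=O)O1` (half-life 2.1 h)

Of the two exact numbers, the lower belongs to compound 1, so it disappears faster than compound 3. In this assay compound 1 gives 0.153 h and compound 3 gives 2.1 h, a gap well beyond the usual scatter. For compound 2 the assay reports only a limit, > 3 h.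

Compound 4 `CC(C)C(/C=C1/C(=O)NC(=O)N1C)c1ccc(-c2ccc3cccc(F)c3c2)[nH]c1=O` has not yet been measured. Its difference from compound 1 is a group of 9 heavy atoms (5 carbon, 2 nitrogen, 2 oxygen; one five-membered non-aromatic ring with 2 hetero atoms) in place of a group of 9 heavy atoms (5 carbon, 2 nitrogen, 2 oxygen; one five-membered non-aromatic ring with 2 hetero atoms), on a saturated chain carbon bound to an aromatic carbon and a saturated chain carbon. The swap sits on a saturated chain carbon bound to an aromatic carbon and a saturated chain carbon. The two groups look much alike, but the entering one has 3 double bonds outside aromatic rings in place of 2.

Among the compounds with values here, the only measured guide is compound 3, which also carries this kind of double bond and gives 2.1 h. It differs from compound 1 in other places too, so it is a loose guide. A modest rise is therefore expected, only a little beyond the scatter, and the estimated step is a 2.9-fold higher number from compound 1 to compound 4 (0.47 log units; beyond the scatter). For compound 4 the expected half-life is 0.45 h, with an estimated range from 0.15 h to 1.5 h.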

Compound 4, half-life: > 3 h
Compound 4: a limit, no number; the forecaster's own chance of this, stated with the estimate: 3%; at least 6.6-fold (0.82 log units) between middle value and limit.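

In this assay, within the data shown here, the earlier compounds differ from compound 1 in more than one place, so none of them can isolate a single change, whereas this pair can and gives an at least 19-fold higher number from compound 1 to compound 4 (1.29 log units; beyond the scatter). The (3-methyl-2,5-dioxoimidazolidin-4-yl)methyl group gives way to a group with the same count of heavy atoms and one more double bond outside aromatic rings, so at this position, on a saturated chain carbon bound to an aromatic carbon and a saturated chain carbon, that small change alone moves the half-life well beyond the usual scatter. The step is only a lower bound on the real difference, because the value of compound 4 is a limit and not a number: the limit of > 3 h in this assay, at which 2 of the 4 values shown sit.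

The compounds shown leave open whether the new double bond would give a similar step with another group in place of the five-membered ring, such as a carboxylic acid or a simple amide. They also leave open how a saturated counterpart of compound 3 would compare with compound 3 itself.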